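Fluoro for Trifluoromethoxy: Cytotoxicity Expected to Stay at the Limit

A few compounds are considered here, and "the series" means these few. Any claim that something is new, unique, unknown or untested is made for them only; others in the source may bear on it.

Three compounds on a shared core have been examined in an ADME assay on Vero cells (Chlorocebus sabaeus) for cytotoxicity, with a stated time of 72 h; a higher number here means a weaker inhibitor, a lower number a stronger inhibitor. Compound 1 `O=[N+]([O-])c1cn2c(n1)OC[C@@H](OCc1ccc(-c3ccc(OC(F)(F)F)cc3)cc1Cl)C2` reaches only a limit of the assay there, giving > 128000 nM. Compound 2 `O=[N+]([O-])c1cn2c(n1)OC[C@@H](OCc1ccc(-c3ccc(C(F)(F)F)cn3)cc1F)C2` likewise reaches only a limit, giving > 128000 nM. Compound 3 `O=[N+]([O-])c1cn2c(n1)OCC(COc1ccc(-c3ccc(OC(F)(F)F)cc3)cc1)C2` also sits at a limit in this assay, with > 128000 nM. Compound 3 therefore cannot be placed against the others, because the limit of > 128000 nM in this assay, at which 3 of the 3 values shown sit, is where every value rests and no number is known for any of them.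

Compound 4 `O=[N+]([O-])c1cn2c(n1)OCC(COc1ccc(-c3ccc(F)cc3)cc1)C2` differs from compound 3 in one place: fluoro in place of trifluoromethoxy on an aromatic carbon. Within the data shown here, no step between two measured compounds is available to gauge this exchange, so the expectation rests on compound 3 alone, whose value > 128000 nM is a limit. The author expects no step beyond the scatter, and estimates the step from compound 3 to compound 4 in this assay as a step that the limit leaves unreadable from compound 3 to compound 4. Compound 4 is estimated at 150000 nM, with a range from 90000 nM to 300000 nM, and most likely the assay will again report only a limit.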

Compound 4, half-maximal inhibitory concentration: > 128000 nM
Compound 4: a limit, no number; the forecaster's own chance of this, stated with the estimate: 85%; the middle value is on the limit's open side.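

In this assay compound 4 gives > 128000 nM as well, a limit and not a number. Among these compounds, no step from compound 3 to compound 4 can be read: the limit of > 128000 nM in this assay, at which 4 of the 4 values shown sit. The compounds shown leave open how far each lies from that limit, and whether any exchange on the shared core matters in this assay at all.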